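Working notes: hexyl removal on the shared core

A few compounds are considered here, and "the series" means these few. Any claim that something is new, unique, unknown or untested is made for them only; others in the source may bear on it.

Compound 3 `CCCCCCc1ccc2c(ccn2C(=O)CCCC(=O)O)c1` gives 17700 nM in a functional assay on isolated protein for antagonist activity at Oxoeicosanoid receptor 1 (Homo sapiens), read by fluorescence and calcium flux, with stated times of 2 min and 1 min (a higher number here means a weaker inhibitor, a lower number a stronger inhibitor), the highest of the three numbers in hand. Compound 1 `CCCCCCc1cccc2ccn(C(=O)CCCC(=O)O)c12` gives 11800 nM in this assay, within the scatter of compound 3. Compound 2 `O=C(O)CCCC(=O)n1ccc2ccc(Cl)cc21` gives 400 nM in this assay, beyond the scatter and far below compound 3. Compound 4 `O=C(O)CCCC(=O)n1ccc2ccccc21` is not yet measured. The change from compound 3 is hydrogen in place of hexyl on an aromatic carbon. Within the data shown here, no single-change step between measured compounds is available, so the size of this step is unknown from the data. Compound 2, which also lacks the hexyl chain, gives 400 nM in this assay. On that basis a lower number for compound 4 is expected, by an uncertain margin. The expected step is a 5.9-fold lower number from compound 3 to compound 4 (0.77 log units; beyond the scatter). Compound 4 is estimated at 3000 nM, between 500 nM and 18000 nM.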

Compound 4, half-maximal inhibitory concentration: > 30000 nM
Compound 4: a limit, no number (the forecaster's own chance of this, stated with the estimate: 10%); at least 10-fold (1.00 log units) between middle value and limit.
By their numbers in this assay, from the lowest: compound 2; then compounds 1 and 3 (each within the scatter of the next). At a limit, above all of these: compound 4.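

In this assay compound 4 gives > 30000 nM, a limit and not a number. Hydrogen in place of chloro gives an at least 75-fold higher number from compound 2 to compound 4 (1.87 log units; beyond the scatter), so the low number of compound 2 rests on the chloro and not on the absence of hexyl. Hydrogen in place of hexyl gives an at least 2.5-fold higher number from compound 1 to compound 4 (0.40 log units; beyond the scatter), a step beyond the scatter even at its floor, while an at least 1.6-fold higher number from compound 3 to compound 4 (0.22 log units; that floor lies within the scatter) leaves that floor within the scatter.

From the compounds shown here alone, the true size of all three steps stays open. Going by these compounds, whether bromo or a shorter chain such as methyl could stand in for chloro also stays open.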